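The compounds below may be only part of what the source reports. "The series", "measured", "known", "first", "only" and "open" are said of these compounds alone.

Measured so far: compound 1 `O=C(Nc1cc(-c2ccccc2)nn1-c1ccccc1)c1cccc(F)c1` gives 65 nM; compound 2 `O=C(Nc1cc(-c2ccccc2)nn1-c1ccccc1)c1ccsc1` gives 2900 nM; compound 3 `O=C(Nc1cc(-c2ccccc2)nn1-c1ccccc1)c1cnccn1` gives 400 nM, all in an assay on isolated protein with metabotropic glutamate receptor 5 (Rattus norvegicus) as the target; on this read-out higher numbers stand for an effect only at larger amounts of compound and lower numbers for an effect already at smaller amounts.

Compound 3 stands second highest of the three numbers: compound 1 lies a 6.2-fold higher number from compound 1 to compound 3 (0.79 log units; beyond the scatter) from it, while compound 2 lies a 7.3-fold lower number from compound 2 to compound 3 (0.86 log units; beyond the scatter). The next compound, compound 4 `O=C(Nc1cc(-c2ccccc2)nn1-c1ccccc1)c1ccc(C(F)(F)F)cc1`, differs from compound 3 in one place: 4-(trifluoromethyl)phenyl in place of pyrazin-2-yl on a carbonyl carbon. Going by the values given here, the step that bears most on this change is the one from compound 1 to compound 3, where a carbon-only six-membered ring gave way to pyrazin-2-yl and the number rose by a 6.2-fold higher number from compound 1 to compound 3 (0.79 log units; beyond the scatter). Returning to a carbon-only six-membered ring is therefore expected to bring the number down, with the step estimated at a 4.0-fold lower number from compound 3 to compound 4 (0.60 log units; beyond the scatter). For compound 4 in this assay the estimate is 100 nM, within a range of 25 nM to 400 nM.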

Compound 4, half-maximal effective concentration: 20 nM
Compound 4: the middle estimate sits 5.0-fold (0.70 log units) above what was measured; measured number outside the range, below it.
By their numbers in this assay, from the lowest: compound 4; then compound 1; then compound 3; then compound 2.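

In this assay the place on the carbonyl carbon accepts 4-(trifluoromethyl)phenyl, with its 10 heavy atoms, and this gives a 20-fold lower number from compound 3 to compound 4 (1.30 log units; beyond the scatter) and a 150-fold lower number from compound 2 to compound 4 (2.16 log units; beyond the scatter). The group also goes beyond 3-fluorophenyl, with a 3.3-fold lower number from compound 1 to compound 4 (0.51 log units; beyond the scatter), so a carbon-only ring here is not limited to the level of compound 1. Compound 4 therefore has the lowest number of the four, and each of its steps lies beyond the scatter.

Nothing at hand explains the size of these steps. As far as these compounds go, whether the trifluoromethyl group itself carries the change stays open, as does what a methoxy group or an amine would give on the same phenyl ring.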